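Cytotoxicity notes: chlorophenyl to trifluoromethylphenyl on the shared core

The source may report more compounds than this note shows. Statements on the series, on what has been measured and on what is new or still open speak of the compounds shown alone.

Measured so far:
compound 1 `COc1ccc([C@@H]2OC[C@H]3O[C@@H](c4ccccc4)[C@H](OC)[C@@H](OC)[C@@H]3O2)cc1` — "not determined" (no result reported)
compound 2 `CO[C@@H]1[C@@H](OC)[C@H](c2ccccc2)O[C@@H]2CO[C@@H](c3ccc(Cl)cc3)O[C@@H]12` — >= 100 ug/mL
compound 3 `CO[C@@H]1[C@@H](OC)[C@H](c2ccccc2)O[C@@H]2CO[C@@H](c3cccc(Cl)c3)O[C@@H]12` — >= 40 ug/mL

Three analogues share one core and differ at the aryl group on a saturated ring carbon. In a functional assay on HEL cells (Homo sapiens) for cytotoxicity (on this read-out lower numbers stand for higher toxicity in this test and higher numbers for lower toxicity in this test), compound 1 has "not determined" (no result reported). For compound 2 the value >= 100 ug/mL is a limit of this assay, not a number. For compound 3 the value >= 40 ug/mL is likewise a limit, not a number. Within the data shown here, the only single-point change among measured compounds is a step that the two limits leave unreadable from compound 2 to compound 3; both ends are limits, as the limit of >= 100 ug/mL in this assay, at which 1 of the 3 values shown sits, and the limit of >= 40 ug/mL in this assay, at which 1 of the 3 values shown sits, show, so nothing can be read from it about how aryl substitution moves toxicity.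

Compound 4 `CO[C@@H]1[C@@H](OC)[C@H](c2ccccc2)O[C@@H]2CO[C@@H](c3ccc(C(F)(F)F)cc3)O[C@@H]12` is not yet measured. It differs from compound 3 by 4-(trifluoromethyl)phenyl in place of 3-chlorophenyl on a saturated ring carbon. Among the measured compounds shown here, no measured step bears on a trifluoromethyl group, and the one chlorophenyl step is unreadable, so no direction beyond the scatter is expected. Compound 4 is expected to sit near the limits seen, with an estimated step that the limit leaves unreadable from compound 3 to compound 4 and an estimated value of 60 ug/mL in the range 20 ug/mL to 100 ug/mL.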

Compound 4, minimum cytotoxic concentration: >= 16 ug/mL
Compound 4 ended at the assay's limit; the forecaster's own chance of this, stated with the estimate: 70%; the middle value is on the limit's open side.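

In this assay compound 4 gives >= 16 ug/mL, a limit and not a number; its steps from compound 2 and from compound 3 cannot be read. The compounds shown leave open whether changing the aryl group on the shared core moves toxicity at all.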